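Removing the Remaining Methoxy: Compound 2 to Compound 3

The source may report more compounds than this note shows. Statements on the series, on what has been measured and on what is new or still open speak of the compounds shown alone.

Compound 1 `COc1ccc(N(CCNC(C)=O)c2cccc(OC)c2)cc1` and compound 2 `COc1ccc(N(CCNC(C)=O)c2ccccc2)cc1` share a core and differ in one place. In an assay on NIH3T3 cells for displacement of a labelled ligand from melatonin receptor type 1B (Homo sapiens) (on this read-out lower numbers stand for stronger inhibition and higher numbers for weaker inhibition), compound 1 gives 0.871 nM, and compound 2 gives 27.5 nM. Within the data shown here, compound 2 stands highest of the two numbers so far; its nearest neighbour is compound 1, reached by the step of a 32-fold higher number from compound 1 to compound 2 (1.50 log units; beyond the scatter), which arose from hydrogen in place of methoxy on an aromatic carbon.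

Compound 3 `CC(=O)NCCN(c1ccccc1)c1ccccc1` has not yet been measured in this assay. It differs from compound 2 in this way: hydrogen in place of methoxy on an aromatic carbon. Among the measured compounds shown here, the only measured step, a 32-fold higher number from compound 1 to compound 2 (1.50 log units; beyond the scatter), removes the same kind of group from the other ring and therefore bears directly on this change; a further rise of broadly similar size is expected, though the place on the ring is not the same. For compound 3 the estimated number in this assay is 300 nM, within a range from 60 nM to 1500 nM. That estimate would mean an 11-fold higher number from compound 2 to compound 3 (1.04 log units; beyond the scatter).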

Compound 3, inhibition constant: 3.89 nM
Beside the measured number, compound 3's estimate is 77-fold (1.89 log units) above it, outside the stated range (below it).
By their numbers in this assay, from the lowest: compound 1; then compound 3; then compound 2.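

In this assay, among these compounds, replacing methoxy with hydrogen on the aromatic carbon para to a large group gives a 7.1-fold lower number from compound 2 to compound 3 (0.85 log units; beyond the scatter), so this position does not tolerate the group in the way the earlier compounds might have suggested. The same replacement on the other ring gave a 32-fold higher number from compound 1 to compound 2 (1.50 log units; beyond the scatter), which shows that the direction of this change depends on where the methoxy sits, at least among these three compounds. Nothing available here accounts for the two steps running in opposite directions.

The compounds shown leave open whether a different group at this place, such as a fluorine, an ethoxy or an amine, would give a lower or a higher number than hydrogen. They also leave open whether this step would keep its direction and size with a methoxy still present on the other ring.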